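The source may hold more compounds than are shown below. What is called first, only, known or untested is meant among the compounds shown, and "the series" means these compounds.

Compound 3 `COc1cc(Cl)cc(-c2nn(-c3cccc(NC(=O)Nc4ccc(Cl)c(C(F)(F)F)c4)c3)cc2-c2ccncc2)c1` is one of three analogues sharing a diaryl urea core. In a functional assay on HOP-62 cells (Homo sapiens) for inhibition, read by sulforhodamine B assay, with a stated time of 48 h, tested at 0.01 uM (on this read-out higher numbers stand for a weaker effect at the one concentration tested and lower numbers for a stronger effect), compound 3 gives 100%; compound 1 `O=C(Nc1cccc(-n2cc(-c3ccncc3)c(-c3cc(O)cc(Cl)c3)n2)c1)Nc1ccc(Cl)c(C(F)(F)F)c1` gives 99% and compound 2 `O=C(Nc1cccc(-n2cc(-c3ccncc3)c(-c3cc(O)cc(Cl)c3)n2)c1)Nc1ccc(Cl)c(Cl)c1` gives 105%, and both differences from compound 3 lie within the usual scatter. Compound 4 `COc1cc(Cl)cc(-c2nn(-c3cccc(NC(=O)Nc4ccc(Cl)c(Cl)c4)c3)cc2-c2ccncc2)c1` differs from compound 3 by one change: chloro in place of trifluoromethyl on an aromatic carbon. The same change has been seen once before, as a number 6 percentage points higher from compound 1 to compound 2 (within the scatter), a shift that stayed within the scatter. The step from compound 3 to compound 4 is therefore expected to be of the same small size, a number 4 percentage points higher from compound 3 to compound 4 (within the scatter), with no change beyond the scatter. Compound 4 is estimated to give 104% in this assay, within 92% to 116%.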

Compound 4, a percentage reported as activity, at one concentration (the size of the read-out at that concentration, not a potency): 92%
Estimate against measurement, compound 4: 12 percentage points above; measured number inside the range.
By their numbers in this assay, from the lowest: compounds 4, 1, 3 and 2 (each within the scatter of the next, the first and the last beyond it).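

The step of a number 8 percentage points lower from compound 3 to compound 4 (within the scatter) shows that chloro in place of trifluoromethyl stays small on a second core, so across both cores this change has not moved the number in this assay beyond the scatter: the same change on two cores in this assay, a number 6 percentage points higher (within the scatter) from compound 1 to compound 2 and a number 8 percentage points lower (within the scatter) from compound 3 to compound 4, 14 percentage points apart, within the scatter of two such steps

The methyl on the oxygen gives the one step here beyond the scatter, a number 13 percentage points lower from compound 2 to compound 4 (beyond the scatter), yet the same change stays small on the other pair: the same change on two cores in this assay, a number 1 percentage points higher (within the scatter) from compound 1 to compound 3 and a number 13 percentage points lower (beyond the scatter) from compound 2 to compound 4, 14 percentage points apart, within the scatter of two such steps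

Open, on these data alone, is whether a bromo or a nitrile in this place, or an amine in place of that oxygen, would shift the number at all. The single concentration also leaves open how strong the effect of these four compounds would be at any other concentration.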